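The source may report more compounds than this note shows. Statements on the series, on what has been measured and on what is new or still open speak of the compounds shown alone.

Measured in a functional assay on PC-3 cells (Homo sapiens) for cytotoxicity, read by MTT assay, with a stated time of 72 h; a lower number here means a stronger inhibitor, a higher number a weaker inhibitor:
- compound 1 `COc1ccc(C(=O)c2cc(OC)c(OC)c(OC)c2)cc1N`: 1100 nM
- compound 2 `COc1ccc(C(=O)c2cc(OC)c(OC)c(OC)c2)cc1NC(=O)/C=C/c1cc(OC)c(OC)c(OC)c1`: 3900 nM
- compound 3 `COc1cc(C(=O)c2cc(OC)c(OC)c(OC)c2)cc(NC(=O)/C=C/c2cc(OC)c(OC)c(OC)c2)c1OC`: 4800 nM

Compound 3 gives the highest of the three numbers in this assay. Its nearest neighbour is compound 2, and the step of a 1.2-fold higher number from compound 2 to compound 3 (0.09 log units; within the scatter) lies within the scatter, so the two are not separated. Compound 1 stands furthest away, with a lower number that lies beyond the scatter.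

Compound 4 `COc1ccc(/C=C/C(=O)Nc2cc(C(=O)c3cc(OC)c(OC)c(OC)c3)cc(OC)c2OC)cc1N` is not yet measured. Relative to compound 3 the change is 3-amino-4-methoxyphenyl in place of 3,4,5-trimethoxyphenyl on a double-bonded chain carbon bound to a double-bonded chain carbon. For the measured compounds named here, no measured step bears on this change: the only step on record, a 1.2-fold higher number from compound 2 to compound 3 (0.09 log units; within the scatter), concerns a methoxy on the core and says nothing about the aryl group on the chain. What can be said is that compound 1, which carries the 3-amino-4-methoxyphenyl as its own core, gives a lower number than compound 2 and compound 3 in this assay, but that pair is not a single-point step and is not a basis for a direction. The expected step of a 1.6-fold lower number from compound 3 to compound 4 (0.20 log units; within the scatter) is therefore small and uncertain. For compound 4 the estimate is 3000 nM, with a range of 1200 nM to 7500 nM.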

Compound 4, half-maximal inhibitory concentration: 11100 nM
The estimate for compound 4 lay 3.7-fold (0.57 log units) below the measured number, outside the stated range (above it).
By their numbers in this assay, from the lowest: compound 1; then compounds 2 and 3 (each within the scatter of the next); then compound 4.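

In this assay, for the compounds shown here, the aryl group on the double-bonded chain carbon affects the number: 3-amino-4-methoxyphenyl in place of 3,4,5-trimethoxyphenyl gives a 2.3-fold higher number from compound 3 to compound 4 (0.36 log units; beyond the scatter) and is the first single-place step beyond the scatter. Going by these compounds alone, the only earlier step, a 1.2-fold higher number from compound 2 to compound 3 (0.09 log units; within the scatter) on the core, separated no pair, so this chain position is the first place where one change moves the number in a readable way, here upward and modestly. No data at hand account for this step.

The exchange alters more than one substituent on the ring at once, so the contribution of the amino group cannot be separated from that of the methoxy groups. On these data alone, how a 3-hydroxy-4-methoxyphenyl or a plain phenyl on this chain carbon would compare remains open, as does whether the same exchange on the core of compound 2 would give a similar step.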